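Methylsulfonylphenyl replaces fluoro-trifluoromethylphenyl in a weakly cytotoxic series

The source may hold more compounds than are shown below. What is called first, only, known or untested is meant among the compounds shown, and "the series" means these compounds.

Compound 3 `COc1cc2c(=O)c(C(=O)c3ccc(C)cc3)cn(Cc3ccc(C(F)(F)F)cc3F)c2cc1OC` stands in an ADME assay on Huh-7 cells (Homo sapiens) for cytotoxicity (on this read-out higher numbers stand for weaker inhibition of growth and lower numbers for stronger inhibition of growth), at a limit of the assay, > 25000 nM (the limit of > 25000 nM in this assay, at which 1 of the 3 values shown sits). Compound 1 `COc1cc2c(=O)c(C(=O)c3ccc(C)cc3)cn(Cc3ccc(N)cc3)c2cc1OC` is reported in this assay as "not active" (no number reported), without a number. Compound 2 `COc1cc2c(=O)c(C(=O)c3ccc(C)cc3)cn(CC3CCCCC3)c2cc1OC` gives 22000 nM in this assay. Going by the values given here, the one step with numbers, an at least 1.1-fold higher number from compound 2 to compound 3 (0.05 log units; that floor lies within the scatter), exchanges the group on a saturated chain carbon bound to an aromatic nitrogen. Compound 4 `COc1cc2c(=O)c(C(=O)c3ccc(C)cc3)cn(Cc3ccc(S(C)(=O)=O)cc3)c2cc1OC` differs from compound 3 in 4-(methylsulfonyl)phenyl in place of 2-fluoro-4-(trifluoromethyl)phenyl on a saturated chain carbon bound to an aromatic nitrogen. No measured step involves a methylsulfonyl group, so there is no measured precedent for its direction; the only shown step lies within the scatter. The step that the limit leaves unreadable from compound 3 to compound 4 is therefore expected to stay within the scatter. Compound 4 is estimated at 30000 nM, in a range from 12000 nM to 80000 nM.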

Compound 4, concentration for 50% growth inhibition: > 50000 nM
Compound 4 was reported as a limit (the forecaster's own chance of this, stated with the estimate: 60%); middle value at least 1.6-fold (0.22 log units) away from the limit.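

In this assay, 4-(methylsulfonyl)phenyl in place of cyclohexyl on a saturated chain carbon bound to an aromatic nitrogen gives an at least 2.2-fold higher number from compound 2 to compound 4 (0.35 log units; beyond the scatter), the only step shown at this place that lies beyond the scatter. The value of compound 4 is a limit of the assay: the limit of > 50000 nM in this assay, at which 1 of the 4 values shown sits. The step between compound 3 and compound 4 cannot be read, so neither benzyl group can be ranked against the other.

From the compounds shown here alone, how far compound 4 lies past its limit stays open. So does whether a 4-carboxyphenyl group or a longer chain at this place would give a measurable number.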